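The compounds below may be only part of what the source reports. "The series", "measured", "known", "first", "only" and "open" are said of these compounds alone.

Compounds measured so far:
- compound 1 `O=C(Nc1ccc(Sc2nc3ccccc3s2)c(Cl)c1)c1cc(Br)cc(Br)c1`: in an assay for inhibition of HSP60/HSP10 (Homo sapiens), with a stated time of 60 min (on this read-out higher numbers stand for weaker inhibition and lower numbers for stronger inhibition), compound 1 gives > 100000 nM, which is a limit of the assay and not a number.
- compound 2 `O=C(Nc1ccc(Sc2nc3ccccc3s2)c(Cl)c1)c1cccc(Br)c1O`: in this assay compound 2 gives 6900 nM.

Compound 2 thus holds the only number shown; the other value sits at the limit of > 100000 nM in this assay, at which 1 of the 2 values shown sits. Among the measured compounds shown here, the single measured step, an at least 14-fold lower number from compound 1 to compound 2 (1.16 log units; beyond the scatter), was large and beyond the scatter. Compound 3 `COc1c(Br)cc(Br)cc1C(=O)Nc1ccc(Sc2nc3ccccc3s2)c(Cl)c1` differs from compound 2 by a group of 10 heavy atoms (7 carbon, 1 oxygen, 2 bromine; one six-membered aromatic ring of carbon only) in place of a group of 8 heavy atoms (6 carbon, 1 oxygen, 1 bromine; one six-membered aromatic ring of carbon only), on a carbonyl carbon. The entering group carries two bromines and no hydrogen-bond donor, which brings it closer to the 3,5-dibromophenyl of compound 1 than to the 3-bromo-2-hydroxyphenyl of compound 2. Since that measured step ran strongly in favour of the hydroxyl-bearing group, compound 3 is expected to lose ground against compound 2, with an estimated step of a 5.8-fold higher number from compound 2 to compound 3 (0.76 log units; beyond the scatter). For compound 3 the estimate in this assay is 40000 nM, with a range from 8000 nM to 150000 nM.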

Compound 3, half-maximal inhibitory concentration: > 100000 nM
Compound 3: no number, only a limit; the forecaster's own chance of this, stated with the estimate: 45%; middle value at least 2.5-fold (0.39 log units) from the limit.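

In this assay, the group on the carbonyl carbon that carries methoxy and two bromines gives an at least 14-fold higher number from compound 2 to compound 3 (1.16 log units; beyond the scatter), so an oxygen on the aromatic ring does not by itself keep the number seen with the 3-bromo-2-hydroxyphenyl group. Among the compounds shown here, the value of compound 3 is a limit and not a number, and it joins the only other value of that kind: the limit of > 100000 nM in this assay, at which 2 of the 3 values shown sit. Both ends of the step from compound 1 to compound 3 are limits, and that step cannot be read.

This change swaps the hydroxyl for methoxy and adds a second bromine at once, so the compounds shown do not separate the two. A phenyl carrying hydroxyl with two bromines, one carrying methoxy with a single bromine, or an amine in place of the hydroxyl would each bear on that question.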